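Swapping a Ring Hydrogen for an Amino Group

The source may hold more compounds than are shown below. What is called first, only, known or untested is meant among the compounds shown, and "the series" means these compounds.

Compound 1 `ClCc1ccccc1Cn1cnc2c(Cl)nc(Cl)nc21` gives 1310 nM in a functional assay on UACC-62 cells (Homo sapiens) for cytotoxicity, read by sulforhodamine B assay, with a stated time of 48 h; a lower number here means a stronger inhibitor of growth, a higher number a weaker inhibitor of growth.
Compound 2 `ClCc1ccccc1Cn1cnc2c(Cl)ncnc21` gives 3310 nM.
Compound 3 `ClCc1ccc(Cn2cnc3c(Cl)nc(Cl)nc32)cc1` gives 2040 nM.

Of the three numbers in this assay, that of compound 2 is the highest; compound 3 sits within the scatter of it, so the two cannot be told apart, while compound 1 lies beyond it. Compound 4 `Nc1nc(Cl)c2ncn(Cc3ccccc3CCl)c2n1` differs from compound 2 by amino in place of hydrogen on an aromatic carbon. Among the measured compounds shown here, no measured step adds an amino group, but the same aromatic carbon was varied once: a 2.5-fold higher number from compound 1 to compound 2 (0.40 log units; beyond the scatter), a modest step. A step of similar modest size is therefore expected for compound 4, most likely toward a lower number: a 1.7-fold lower number from compound 2 to compound 4 (0.22 log units; within the scatter). Compound 4 is expected to give 2000 nM, with a range from 700 nM to 6000 nM.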

Compound 4, concentration for 50% growth inhibition: 2240 nM
The estimate for compound 4 lay 1.1-fold (0.05 log units) below the measured number, within the range that was stated.
By their numbers in this assay, from the lowest: compounds 1, 3, 4 and 2 (each within the scatter of the next, the first and the last beyond it).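

At this aromatic carbon, between two ring nitrogen atoms, amino cannot be told apart from hydrogen in this assay: a 1.5-fold lower number from compound 2 to compound 4 (0.17 log units; within the scatter). It cannot be told apart from chloro either: a 1.7-fold higher number from compound 1 to compound 4 (0.23 log units; within the scatter), even though chloro and hydrogen do differ beyond the scatter, so amino falls within reach of both. Nothing shown gives a reason for these steps. Still open, from the compounds shown here alone, is how a methoxy group or a carboxylic acid would behave at this carbon. Also open, going by these compounds, is whether amino would give a similar result on the core of compound 3.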